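This account rests on a few compounds, and the source may have more. Where it says the series, first, only, none or still open, it means among the compounds named here.

Compound 2 `CC1(C)CC(=O)C2=C(C1)NC(c1ccccc1)=CC2c1ccc([N+](=O)[O-])cc1` carries a nitro group on its pendant aromatic ring. In an assay on isolated protein for inhibition of glucose-6-phosphatase catalytic subunit 1 (Homo sapiens), read by inositol phosphate accumulation, with a stated time of 30 min, tested at 100 uM (on this read-out lower numbers stand for less inhibition and higher numbers for more inhibition at the one concentration tested (going by the name of the read-out)), compound 2 is recorded only as "not active" (no number reported), with no number behind it, and it is not alone in this: compound 3 `CCOC(=O)C1(O)CC(c2ccc(OC)cc2)C2=C(CC(C)(C)CC2=O)O1`, built on a different core, is likewise recorded in this assay as "not active" (no number reported). Among the compounds with values here, the one compound of the set that does give a number, compound 1 `CC1(C)CC(=O)C2=C(C1)NC(c1ccccc1)=CC2c1ccco1`, shows in this assay 11.4%, a small inhibition at the single concentration tested.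

Compound 4 `CC1(C)CC(=O)C2=C(C1)NC(c1ccccc1)=CC2c1ccc(Cl)cc1` is the counterpart of compound 2 with a single change: chloro in place of nitro on an aromatic carbon. Within the data shown here, no step between measured compounds is available to size what such a change does, and the only numbered neighbour, compound 1, sits near the bottom of the scale. Any movement from compound 2 to compound 4 in this assay is therefore expected to be small, most likely none beyond the scatter, and compound 4 is expected to stay in the region of weak inhibition. For compound 4 in this assay the estimate is 8%, within a range from 0% to 22%.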

Compound 4, a percentage reported as inhibition, at one concentration (the size of the read-out at that concentration, not a potency): 7.16%
Beside the measured number, compound 4's estimate is 0.8 percentage points above it; the range from low to high includes it.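

In this assay, within the data shown here, compound 4 gives a number where compound 2 has none, so the change from 4-nitrophenyl to 4-chlorophenyl yields no step that can be read, and its size remains unknown. Placing 4-chlorophenyl instead of furan-2-yl on the saturated ring carbon gives a number 4.2 percentage points lower from compound 1 to compound 4 (within the scatter), so the printed numbers do not separate these two groups at this position. Nothing measured here offers an explanation for either result.

The compounds shown leave open whether an amine or a carboxylic acid in place of chloro on the aromatic ring would move the inhibition beyond the usual scatter. They also leave open whether a saturated amine ring in place of furan-2-yl would change the reading on the shared core.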